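The compounds below may be only part of what the source reports. "The series", "measured", "known", "first", "only" and "open" are said of these compounds alone.

Compound 1 (`COc1cc(CCc2ccncc2)cc(OC)c1O`) gives > 25000 nM
Compound 2 (`COc1cc(CCc2ccccc2)cc(OC)c1O`) gives 10900 nM
Compound 3 (`COc1cc(CCc2ccccc2Cl)cc(OC)c1O`) gives 2130 nM

All values come from a functional assay on A549 cells (Homo sapiens) for antiproliferative activity, read by MTT assay, with a stated time of 72 h (a higher number here means a weaker inhibitor, a lower number a stronger inhibitor), in this series. The entry for compound 1 (> 25000 nM) is a limit, not a number. Compound 2 (10900 nM) holds the higher of the two actual numbers, with compound 3 nearest. Compound 4 (`COc1cc(CCc2ccc(Br)cc2)cc(OC)c1O`) comes next, and the change is bromo in place of hydrogen on an aromatic carbon (bromo in place of hydrogen on an aromatic carbon, para to a large group). The closest measured step (a 5.1-fold lower number from compound 2 to compound 3 (0.71 log units; beyond the scatter)) is chloro in place of hydrogen on an aromatic carbon. The other step (an at least 2.2-fold lower number from compound 1 to compound 2 (0.36 log units; beyond the scatter)) swaps pyridin-4-yl for phenyl and bears little on this change. Among the compounds with values here, with only one such precedent, a lower number of somewhat smaller size is expected in this assay. The expected step is (a 2.9-fold lower number from compound 2 to compound 4 (0.46 log units; beyond the scatter)). For compound 4 the estimated value is 3800 nM with an expected range (1400 nM to 10000 nM).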

Compound 4, half-maximal inhibitory concentration: > 25000 nM
Compound 4 gave a limit, no number; the forecaster's own chance of this, stated with the estimate: 4%; middle value at least 6.5-fold (0.81 log units) from the limit.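

In this assay, bromo in place of hydrogen on an aromatic carbon, para to a large group, gives an at least 2.2-fold higher number from compound 2 to compound 4 (0.36 log units; beyond the scatter). This change therefore does not follow the direction of the chloro step, a 5.1-fold lower number from compound 2 to compound 3 (0.71 log units; beyond the scatter). Compound 4 carries a limit, not a number, so its step gives a direction and a minimum size only: the limit of > 25000 nM in this assay, at which 2 of the 4 values shown sit.

Open, going by these compounds, is whether the difference belongs to the halogen or to its place: chloro para to a large group, or bromo where compound 3 bears chloro, would separate the two. A methoxy group or an amine at the para place would show whether any group other than a halogen keeps activity there.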